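Swapping the Distal Aryl Group for a tert-Butylphenyl

A few compounds are considered here, and "the series" means these few. Any claim that something is new, unique, unknown or untested is made for them only; others in the source may bear on it.

Compound 2 `COC(=O)/C=C/c1cccc(N(Cc2ccc(-c3c(OC)cccc3OC)cc2)C(=O)C2CCCCC2)c1` gives 77 nM in an assay on isolated protein with Bile acid receptor (Homo sapiens) as the target (a lower number here means that less compound is needed, a higher number that more compound is needed for the effect), the lower of the two numbers recorded so far, although the gap to compound 1 `COC(=O)/C=C/c1cccc(N(Cc2ccc(-c3cccc(Cl)c3)cc2)C(=O)C2CCCCC2)c1`, which gives 94 nM, lies within the scatter. Among the compounds with values here, the one measured step on this aryl group, a 1.2-fold lower number from compound 1 to compound 2 (0.09 log units; within the scatter), stayed within the scatter. Compound 3 `COC(=O)/C=C/c1cccc(N(Cc2ccc(-c3ccc(C(C)(C)C)cc3)cc2)C(=O)C2CCCCC2)c1` differs from compound 2 by 4-(tert-butyl)phenyl in place of 2,6-dimethoxyphenyl on an aromatic carbon. Within the data shown here, with only that small step to go on, the expected change in this assay is none beyond the scatter. Compound 3 is therefore estimated at 85 nM, with a range of 30 nM to 250 nM. This corresponds to an expected 1.1-fold higher number from compound 2 to compound 3 (0.04 log units; within the scatter).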

Compound 3, half-maximal effective concentration: 132 nM
The estimate for compound 3 lay 1.6-fold (0.19 log units) below the measured number; measured number inside the range.
By their numbers in this assay, from the lowest: compounds 2, 1 and 3 (each within the scatter of the next).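

In this assay, 4-(tert-butyl)phenyl, with no hydrogen-bond acceptors, replaces 2,6-dimethoxyphenyl, with two, and gives a 1.7-fold higher number from compound 2 to compound 3 (0.23 log units; within the scatter); against 3-chlorophenyl it gives a 1.4-fold higher number from compound 1 to compound 3 (0.15 log units; within the scatter). Across compounds 1, 2 and 3, three differently substituted phenyl groups at this position therefore give no step beyond the scatter, even with the acceptor count changed. No measurement at hand offers an explanation for these numbers. As far as these compounds go, whether an amine or a carboxylic acid on this aryl group would move the number beyond the scatter remains open.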